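A Third Aromatic Group on a Shared Core

This account rests on a few compounds, and the source may have more. Where it says the series, first, only, none or still open, it means among the compounds named here.

- compound 1 `COc1cccc(/C=C/C(=O)C(=Cc2ccc(F)cc2)C(=O)/C=C/c2cccc(OC)c2OC)c1OC`: 610 nM
- compound 2 `COc1cc(C=C(C(=O)/C=C/c2cccc(OC)c2OC)C(=O)/C=C/c2cccc(OC)c2OC)cc(OC)c1O`: 300 nM

In a functional assay on CNE-2 cells (Homo sapiens) for antiproliferative activity, read by sulforhodamine B assay, with a stated time of 48 h (on this read-out higher numbers stand for weaker inhibition and lower numbers for stronger inhibition), compound 2 has the lower of the two numbers, with compound 1 above it. Compound 3 `COc1cccc(/C=C/C(=O)C(=Cc2ccc(OC)c(OC)c2OC)C(=O)/C=C/c2cccc(OC)c2OC)c1OC` has not yet been measured. It differs from compound 2 in one place, on a double-bonded chain carbon bound to a double-bonded chain carbon: 2,3,4-trimethoxyphenyl replaces 4-hydroxy-3,5-dimethoxyphenyl, (2,3,4-trimethoxyphenyl in place of 4-hydroxy-3,5-dimethoxyphenyl on a double-bonded chain carbon bound to a double-bonded chain carbon).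

For the measured compounds named here, only one measured step bears on this place: a 2.0-fold lower number from compound 1 to compound 2 (0.31 log units; beyond the scatter). That modest step came when 4-hydroxy-3,5-dimethoxyphenyl replaced 4-fluorophenyl. The new swap exchanges one methoxy-bearing group for another, so a smaller step is expected in this assay, slightly upward and probably within the scatter. One step is thin evidence, so the range stays wide. The estimate amounts to an expected 1.3-fold higher number from compound 2 to compound 3 (0.12 log units; within the scatter). For compound 3, the expected value is 400 nM, within an estimated range of 180 nM to 900 nM.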

Compound 3, half-maximal inhibitory concentration: 410 nM
Compound 3: the middle estimate sits 1.0-fold (0.01 log units) below what was measured, and the stated range covers the measured number.
By their numbers in this assay, from the lowest: compounds 2, 3 and 1 (each within the scatter of the next, the first and the last beyond it).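

In this assay, the group that leaves carries a hydrogen-bond donor and the group that enters carries none, yet the result is only a 1.4-fold higher number from compound 2 to compound 3 (0.14 log units; within the scatter) and stays within the scatter. At this place, then, the assay does not tell 2,3,4-trimethoxyphenyl from 4-hydroxy-3,5-dimethoxyphenyl, and it does not clearly tell it from 4-fluorophenyl either, with a 1.5-fold lower number from compound 1 to compound 3 (0.17 log units; within the scatter) also within the scatter; so a methoxy-bearing group here does not by itself separate from the fluorinated one. No measurement shown here accounts for these numbers.

As far as these compounds go, the hydroxy group and the arrangement of the methoxy groups change together in this swap, so their separate contributions stay unknown. Also open, from the compounds shown here alone, is whether a phenyl group carrying an amine or a carboxylic acid at this place would move the number beyond the scatter.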